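A few compounds are considered here, and "the series" means these few. Any claim that something is new, unique, unknown or untested is made for them only; others in the source may bear on it.

Compound 1 `CCOC(=O)c1cccc(-c2n[nH]c3ccccc23)c1` in a functional assay on cells (Platelet, Homo sapiens) for inhibition (a lower number here means a stronger inhibitor, a higher number a weaker inhibitor), gives > 10000 nM, a limit of the assay rather than a number.
Compound 2 `CCOC(=O)c1ccc(-c2nn(Cc3ccccc3Cl)c3ccccc23)cc1` in this assay gives > 10000 nM, again only a limit.
Compound 3 `CCOC(=O)c1ccc(-c2nn(Cc3ccccc3F)c3ccccc23)cc1` in this assay gives > 10000 nM, also a limit.

Compound 3 therefore stands where every measured compound here stands: the limit of > 10000 nM in this assay, at which 3 of the 3 values shown sit. Going by the values given here, none of the three compounds has a readable value, so no compound can be called stronger or weaker than another.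

Among the compounds with values here, only one step between measured compounds is available, a step that the two limits leave unreadable from compound 2 to compound 3, in which fluoro replaces chloro on the same aromatic carbon of the benzyl group. Because both ends of that step are limits, its size cannot be read.

Compound 4 `CCOC(=O)c1ccc(-c2nn(Cc3ccccc3OC)c3ccccc23)cc1` is the next change at that same carbon: methoxy in place of fluoro on an aromatic carbon. The step from compound 2 to compound 3 bears on it in that it alters the same group on the same carbon, but it gives no size to work from, and no other measured change is at hand.

With every measured compound at the limit and no readable step, the expectation for compound 4 is that the change a step that the limit leaves unreadable from compound 3 to compound 4 stays within what the assay cannot resolve. Compound 4 is estimated in this assay at 20000 nM, with a range from 5000 nM to 80000 nM, most likely reported again only as a limit.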

Compound 4, half-maximal inhibitory concentration: > 10000 nM
Compound 4: no number, only a limit (the forecaster's own chance of this, stated with the estimate: 85%); the middle value is on the limit's open side.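

Neither the step from compound 3 to compound 4 nor the step from compound 2 to compound 4 can be read, as compound 4 also gives only a limit, and all the compounds share it: the limit of > 10000 nM in this assay, at which 4 of the 4 values shown sit.

The compounds shown leave open how chloro, fluoro and methoxy on this carbon compare, and whether any compound in this series gives an actual number in this assay.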